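Methoxy in place of methyl on an antiproliferative benzyl group

The source may hold more compounds than are shown below. What is called first, only, known or untested is meant among the compounds shown, and "the series" means these compounds.

For the measured compounds named here, compound 2 `COc1cccc(CNCc2c(C(=O)O)n(Cc3ccc(C)cc3)c3ccccc23)c1` gives 21500 nM in a functional assay on Bel-7402 cells (Homo sapiens) for antiproliferative activity, read by MTT assay, with a stated time of 72 h (a higher number here means a weaker inhibitor, a lower number a stronger inhibitor), and holds the only actual number among the measured compounds. Compound 1 `COc1ccc(Cn2c(C(=O)O)c(CNCc3cccc(O)c3)c3ccccc32)cc1` shows > 50000 nM in this assay as a limit of the assay and not as a number.

Compound 3 `COc1ccc(Cn2c(C(=O)O)c(CNCc3cccc(OC)c3)c3ccccc32)cc1` follows compound 2 except at one place, where methoxy stands in place of methyl on an aromatic carbon, para to a large group. The 4-methylbenzyl thus becomes 4-methoxybenzyl, a difference counted as methoxy in place of methyl on an aromatic carbon in the two structures.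

Going by the values given here, no measured pair of compounds isolates this change. Compound 1 also carries the 4-methoxybenzyl group, but it differs from compound 3 elsewhere as well. Among the compounds with values here, with compound 2 at 21500 nM as the only number to start from, only a small shift toward weaker inhibition is expected, no larger than the usual scatter. The expected size is a 1.2-fold higher number from compound 2 to compound 3 (0.08 log units; within the scatter) in this assay on this reading. In this assay the estimated value for compound 3 is 26000 nM with an expected range from 11000 nM to 50000 nM as the likely span.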

Compound 3, half-maximal inhibitory concentration: 52900 nM
The estimate for compound 3 lay 2.0-fold (0.31 log units) below the measured number; the whole stated range lies below it.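

Methoxy in place of methyl on the aromatic carbon para to a large group gives a 2.5-fold higher number from compound 2 to compound 3 (0.39 log units; beyond the scatter) in this assay, so the 4-methylbenzyl and 4-methoxybenzyl groups are not interchangeable at this position. This is the first step among the compounds shown that can be read, and it runs toward weaker inhibition, a direction that the earlier values alone could not establish for this change. Compound 1 also carries the 4-methoxybenzyl group, but it stands at a limit of the assay and not at a number, so the step to compound 3, methyl in place of hydrogen on an oxygen on the other aromatic ring, cannot be read: the limit of > 50000 nM in this assay, at which 1 of the 3 values shown sits.

Going by these compounds, the change at this position therefore rests on a single pair, and it remains open whether the shift comes with the added oxygen or would also follow from a longer chain such as ethyl, or from a chlorine or an amine at the same carbon. On these data alone, it is equally open whether the step would keep its size with a different group on the other aromatic ring, or with an ester or amide in place of the carboxylic acid.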